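This account rests on a few compounds, and the source may have more. Where it says the series, first, only, none or still open, it means among the compounds named here.

Measured so far in an assay on CHO cells for displacement of a labelled ligand from adenosine receptor A3 (Homo sapiens), read by scintillation counting, with a stated time of 120 min, tested at 10 uM; on this read-out higher numbers stand for more inhibition at the one concentration tested (going by the name of the read-out) and lower numbers for less inhibition:
- Compound 1 `Nc1scc(CN2CCN(c3ccccc3C(F)(F)F)CC2)c1C(=O)c1ccc(Cl)cc1` gives 0%.
- Compound 2 `Nc1scc(CN2CCN(c3cccc(F)c3)CC2)c1C(=O)c1cccc(C(F)(F)F)c1` gives 0%.
- Compound 3 `Nc1scc(CN2CCN(c3c(F)cccc3F)CC2)c1C(=O)c1cccc(C(F)(F)F)c1` gives 0%.

All three compounds share one core, a ring bearing an amino group and a ketone, with a piperazine that carries an aryl group on its second nitrogen. In this assay compound 1 stands level with compounds 2 and 3 at the digits shown; its nearest neighbour is compound 2 and its furthest compound 3, and in both cases the gap lies within the scatter. For the measured compounds named here, the only step among the measured compounds that changes one place, from compound 2 to compound 3, also swaps the aryl group on that ring nitrogen and gives no change at the digits printed from compound 2 to compound 3 (within the scatter).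

Compound 4 `Nc1scc(CN2CCN(c3cccc(F)c3F)CC2)c1C(=O)c1ccc(Cl)cc1` differs from compound 1 in the same place: 2,3-difluorophenyl in place of 2-(trifluoromethyl)phenyl on an amine nitrogen in a ring. That measured step bears directly on this change and showed nothing beyond the scatter, so the step from compound 1 to compound 4 is expected to be no change at the digits printed from compound 1 to compound 4 (within the scatter), with no direction to it. Compound 4 is therefore estimated at 0%, within a range from -10% to 12%.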

Compound 4, a percentage reported as inhibition, at one concentration (the size of the read-out at that concentration, not a potency): 0%
Compound 4: middle estimate and measured number agree at the digits printed; measured number inside the range.
By their numbers in this assay, from the lowest: compounds 1, 2, 3 and 4 (each within the scatter of the next).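

In this assay, for the compounds shown here, the swap to 2,3-difluorophenyl from 2-(trifluoromethyl)phenyl on the ring nitrogen of the piperazine gives no change at the digits printed from compound 1 to compound 4 (within the scatter) and so adds a second flat step at this position, now with a different group leaving and a smaller group entering, and with the other aryl group of compound 1 in place of the one in compounds 2 and 3. Because all four compounds read the same, this read-out does not separate these aryl groups, and a step between two compounds that show no inhibition says little about how much this position matters. Nothing shown here offers an explanation for the lack of inhibition.

On these data alone, it remains open whether a methoxy or hydroxyl group on this aryl ring, or a benzyl group or a simple alkyl chain in its place, would give any inhibition. The same question stands for a carboxylic acid or an amine on the aryl ketone side of the shared core.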